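A few compounds are considered here, and "the series" means these few. Any claim that something is new, unique, unknown or untested is made for them only; others in the source may bear on it.

Working notes on the series. Compound 1 `O=C1C(=O)N(CCCCCn2cc(COc3cc(=O)oc4ccccc34)nn2)c2ccc(F)cc21` and compound 2 `O=C1C(=O)N(CCCCn2cc(COc3cc(=O)oc4ccccc34)nn2)c2ccc(F)cc21` share one core. Among the compounds with values here, in a functional assay on HCT-116 cells (Homo sapiens) for inhibition, read by sulforhodamine B assay, with a stated time of 48 h, tested at 50 uM (on this read-out lower numbers stand for less inhibition of growth and higher numbers for more inhibition of growth at the one concentration tested), compound 1 gives 59%; compound 2 gives 67%, and the two numbers lie within the scatter of each other, so compound 1 stands level with its one measured neighbour. Compound 3 `O=C1C(=O)N(CCCCCn2cc(COc3cc(=O)oc4ccccc34)nn2)c2ccc([N+](=O)[O-])cc21` is the next member. From compound 1 it differs by nitro in place of fluoro on an aromatic carbon. Within the data shown here, no measured pair in the set carries this change, so the expected step of a number 1 percentage points higher from compound 1 to compound 3 (within the scatter) is none beyond the scatter, with no fixed direction. Compound 3 is estimated to give 60% in this assay, within 40% to 78%.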

Compound 3, percent growth inhibition at one concentration: 29%
Compound 3: middle estimate off by 31 percentage points, on the high side; measured number below the stated range.
By their numbers in this assay, from the lowest: compound 3; then compounds 1 and 2 (each within the scatter of the next).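

In this assay the aromatic carbon carrying fluoro in compound 1 proves sensitive to its substituent: nitro in place of fluoro gives a number 30 percentage points lower from compound 1 to compound 3 (beyond the scatter). The earlier compounds shown here, both fluoro, varied only in the chain and could not show this. Nothing measured here accounts for the step. As far as these compounds go, it remains open whether an amine or a nitrile on the same carbon would give a similar step. From the compounds shown here alone, it also remains open whether the step carries over to the shorter chain of compound 2.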